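Lengthening the Chain of Compound 1: An Expectation

The source may report more compounds than this note shows. Statements on the series, on what has been measured and on what is new or still open speak of the compounds shown alone.

Measured compounds:
compound 1, `CCCCCCCCC(=O)c1cc(O)c(O)c(O)c1`, 50000 nM
compound 2, `CCCCCCCCCCCCC(=O)c1cc(O)c(O)c(O)c1`, 47400 nM

In a functional assay on CCRF-CEM cells (Homo sapiens) for cytotoxicity, read by MTT assay, with a stated time of 24 h (a lower number here means a stronger inhibitor, a higher number a weaker inhibitor), compound 1 gives 50000 nM, the highest of the two numbers recorded. Among the compounds with values here, its only neighbour is compound 2, which in this assay gives 47400 nM; the two differ by a 1.1-fold lower number from compound 1 to compound 2 (0.02 log units; within the scatter), so nothing separates them beyond the scatter.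

The step under consideration leads from compound 1 to compound 3, `CCCCCCCCCCCCCCC(=O)c1cc(O)c(O)c(O)c1`, which has not yet been measured in this assay. The change is hexyl in place of hydrogen on a saturated chain carbon, eight bonds along the chain from a carbonyl carbon. Within the data shown here, the one measured step that bears on it is a 1.1-fold lower number from compound 1 to compound 2 (0.02 log units; within the scatter), where a butyl group entered at the same place on the chain and left the number essentially unchanged. The present change puts a hexyl group at that position, a longer version of the same kind of change, and on the evidence of a single step no movement beyond the scatter is expected.

Compound 3 is therefore expected to give about 47000 nM in this assay, with a likely range of 24000 nM to 95000 nM. This estimate amounts to a step of a 1.1-fold lower number from compound 1 to compound 3 (0.03 log units; within the scatter), within the scatter.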

Compound 3, half-maximal inhibitory concentration: > 50000 nM
Compound 3 gave a limit, no number (the forecaster's own chance of this, stated with the estimate: 15%); middle value at least 1.0-fold (0.02 log units) away from the limit.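

In this assay, compound 3 yields a limit of the assay and not a number: the limit of > 50000 nM in this assay, at which 1 of the 3 values shown sits.

Within the data shown here, the earlier pair showed only that a butyl group at this position left the number within the scatter, and hexyl now extends that picture: the longer group brings no lower number, so neither change to the chain of compound 1 has produced a gain in this assay. Among these compounds, the only step that can be read is an at least 1.0-fold higher number from compound 2 to compound 3 (0.02 log units; that floor lies within the scatter), so the data show no separation between the butyl and hexyl changes beyond the scatter, though the limit leaves room for one. The other step is a number no lower from compound 1 to compound 3 (the limit leaves the size open) and cannot be read.

From the compounds shown here alone, how far the true value of compound 3 lies past its limit stays unknown, and with it whether hexyl weakens the compound at all. Also open, going by these compounds, is whether an amine or a carboxylic acid in place of hydrogen on that saturated chain carbon, eight bonds along the chain from a carbonyl carbon, would move the number beyond the scatter where butyl and hexyl did not.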